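Trading a trimethoxyphenyl for a chlorophenyl

A few compounds are considered here, and "the series" means these few. Any claim that something is new, unique, unknown or untested is made for them only; others in the source may bear on it.

Three compounds have been measured in an assay on isolated protein for inhibition of Maltase-glucoamylase (Homo sapiens), with stated times of 15 min and 10 min, tested at 64 uM; a higher number here means more inhibition at the concentration tested (going by the name of the read-out), a lower number less inhibition:
compound 1, `C=CCc1cc(CN2CCC(C)CC2)c(O)c(-c2cc(CC=C)c(O)c(CN3CCC(C)CC3)c2)c1`, gives 6.5%
compound 2, `C=CCc1cc(-c2ccc(O)c(CC=C)c2)c(O)c(C(c2cc(OC)c(OC)c(OC)c2)N2CCCC2)c1`, gives 43%
compound 3, `C=CCc1cc(-c2ccc(O)c(CC=C)c2)c(O)c(C(c2cc(OC)c(OC)c(OC)c2)N2CCCCC2)c1`, gives 56.4%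

Compound 2 stands second highest of the three numbers in this assay. Its nearest neighbour is compound 3, reached by a step of a number 13.4 percentage points higher from compound 2 to compound 3 (beyond the scatter), which comes from piperidin-1-yl in place of pyrrolidin-1-yl on a saturated chain carbon bound to two aromatic carbons. Compound 1 lies furthest from compound 2, well below it.

Compound 4, `C=CCc1cc(-c2ccc(O)c(CC=C)c2)c(O)c(C(c2ccc(Cl)cc2)N2CCCC2)c1`, is not yet measured. It differs from compound 2 in one place:
4-chlorophenyl in place of 3,4,5-trimethoxyphenyl on a saturated chain carbon bound to an amine nitrogen in a ring and an aromatic carbon

For the measured compounds named here, no measured step touches that place. Going by the values given here, the only step in hand, a number 13.4 percentage points higher from compound 2 to compound 3 (beyond the scatter), alters the amine ring and says nothing about the aryl group carried on the same saturated carbon. With no comparable change among the measured compounds, the expectation for compound 4 in this assay rests on compound 2 alone and amounts to a step of a number 3 percentage points lower from compound 2 to compound 4 (within the scatter), which is not beyond the scatter. The estimate for compound 4 is therefore 40%, with a range from 20% to 60%.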

Compound 4, a percentage reported as inhibition, at one concentration (the size of the read-out at that concentration, not a potency): 40.6%
Compound 4: middle estimate off by 0.6 percentage points, on the low side; the range from low to high includes it.
By their numbers in this assay, from the lowest: compound 1; then compounds 4 and 2 (each within the scatter of the next); then compound 3.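

In this assay, the exchange of 3,4,5-trimethoxyphenyl for 4-chlorophenyl on the saturated chain carbon bound to an amine nitrogen in a ring and an aromatic carbon gives a number 2.4 percentage points lower from compound 2 to compound 4 (within the scatter). For the compounds shown here, this is the first reading at this position, and it shows that the aryl group can go from 12 heavy atoms and 3 hydrogen-bond acceptors to 7 heavy atoms and 0 hydrogen-bond acceptors, with a chlorine in place of the oxygens, without a change in inhibition that this read-out can separate from scatter, at least with the pyrrolidin-1-yl amine of these two compounds and at the one concentration tested. Nothing available explains why these two different aryl groups read alike.

The compounds shown leave open whether the same exchange would read alike with the piperidin-1-yl amine of compound 3, the only amine ring change so far, which gives a number 13.4 percentage points higher from compound 2 to compound 3 (beyond the scatter). They also leave open how an unsubstituted phenyl, a pyridine ring or a 4-methoxyphenyl would read on this carbon, and whether the two groups would still match in a full concentration series.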